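The source may hold more compounds than are shown below. What is called first, only, known or untested is meant among the compounds shown, and "the series" means these compounds.

Of the compounds shown here, three of a shared core have been measured in an assay on isolated protein for displacement of a labelled ligand from metabotropic glutamate receptor 5 (Homo sapiens), with a stated time of 60 min, tested at 1 uM; on this read-out higher numbers stand for more inhibition at the one concentration tested (going by the name of the read-out) and lower numbers for less inhibition. Compound 1 `CC1CCN(c2c(S(=O)(=O)c3ccc(Cl)c(Cl)c3)cnc3cc(F)ccc23)CC1` gives 94% in this assay. Compound 2 `COc1ccc(S(=O)(=O)c2cnc3cc(Cl)ccc3c2N2CCC(C)CC2)cc1Cl` gives 93% in this assay. Compound 3 `Cc1ccc2ncc(S(=O)(=O)c3cc(Cl)cc(Cl)c3)c(N3CCC(C)CC3)c2c1` gives 75% in this assay. Among these three numbers compound 2 stands second highest; its nearest neighbour is compound 1, at a gap that lies within the scatter, while its furthest neighbour is compound 3, whose number is lower by a gap that lies beyond the scatter. Compound 1 and compound 2 therefore cannot be ordered against each other, but both sit clearly above compound 3.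

The step under consideration leads from compound 2 to compound 4 `CC1CCN(c2c(S(=O)(=O)c3ccc(F)cc3)cnc3cc(Cl)ccc23)CC1`, which has not yet been measured in this assay. The change is 4-fluorophenyl in place of 3-chloro-4-methoxyphenyl on a sulfonyl sulfur. Among the measured compounds shown here, no measured pair in this set differs in one place, so the size of the step must be expected rather than read off. Compound 4 is expected to remain well above the level of compound 3, because compound 2 gives 93% and the rest of the molecule is unchanged. The step from compound 2 to compound 4 is expected to be a number 13 percentage points lower from compound 2 to compound 4 (beyond the scatter), downward and somewhat beyond the scatter. Compound 4 is estimated at 80%, within a range from 55% to 95%.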

Compound 4, a percentage reported as inhibition, at one concentration (the size of the read-out at that concentration, not a potency): 91%
Estimate against measurement, compound 4: 11 percentage points below; measured number inside the range.
By their numbers in this assay, from the lowest: compound 3; then compounds 4, 2 and 1 (each within the scatter of the next).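

In this assay, among the compounds shown here, the change gives the first step that can be read in this set: a number 2 percentage points lower from compound 2 to compound 4 (within the scatter), with 4-fluorophenyl in place of 3-chloro-4-methoxyphenyl on a sulfonyl sulfur. At this position, then, the read-out does not separate the two groups, even though the entering group has fewer heavy atoms and no hydrogen-bond acceptor, so neither the chlorine nor the methoxy of the leaving group is shown to be needed for a high number at the one concentration tested. Nothing at hand bears on why the two groups read alike.

The remaining pairs differ in more than one place, so their steps cannot be read, and the lower number of compound 3 cannot be tied to any single part of the molecule. On these data alone, it also remains open how a plain phenyl, a pyridine ring or a phenyl carrying a carboxylic acid would read on the same sulfonyl sulfur, and a single-concentration percentage leaves any difference in potency between compound 2 and compound 4 unresolved.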